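Halogen swap on the carbonyl-bound phenyl ring

The source may hold more compounds than are shown below. What is called first, only, known or untested is meant among the compounds shown, and "the series" means these compounds.

Of the compounds shown here, two sharing one core have been tested in a functional assay on BCG823 cells (Homo sapiens) for inhibition, read by MTT assay, with a stated time of 72 h; a higher number here means a weaker inhibitor, a lower number a stronger inhibitor. Compound 1 `CN(C(=O)NC(=O)c1cccc(C(F)(F)F)c1)c1nc(C(F)(F)F)c(C(=O)N/N=C/c2ccccc2C(F)(F)F)s1` gives 7.29 ug/mL, and compound 2 `CN(C(=O)NC(=O)c1ccc(F)c(F)c1)c1nc(C(F)(F)F)c(C(=O)N/N=C/c2ccccc2C(F)(F)F)s1` gives 3.66 ug/mL; of the two, compound 2 shows the lower number, but the step of a 2.0-fold lower number from compound 1 to compound 2 (0.30 log units; within the scatter) is within the scatter. Compound 3 `CN(C(=O)NC(=O)c1ccc(Cl)cc1Cl)c1nc(C(F)(F)F)c(C(=O)N/N=C/c2ccccc2C(F)(F)F)s1` differs from compound 2 by 2,4-dichlorophenyl in place of 3,4-difluorophenyl on a carbonyl carbon. Within the data shown here, the only step that bears on this change is that one from compound 1 to compound 2, and it stayed within the scatter, so no step beyond the scatter is expected in a 1.2-fold higher number from compound 2 to compound 3 (0.09 log units; within the scatter). Compound 3 is therefore estimated at 4.5 ug/mL, in a range from 1.8 ug/mL to 11 ug/mL.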

Compound 3, half-maximal inhibitory concentration: 5.73 ug/mL
Estimate against measurement, compound 3: 1.3-fold (0.10 log units) below; low and high end bracket the measured number.
By their numbers in this assay, from the lowest: compounds 2, 3 and 1 (each within the scatter of the next).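

In this assay the step of a 1.6-fold higher number from compound 2 to compound 3 (0.19 log units; within the scatter) and the step of a 1.3-fold lower number from compound 1 to compound 3 (0.10 log units; within the scatter) both stay within the scatter, so all three phenyl groups tried on this carbonyl carbon now give numbers that cannot be told apart. Chlorine in place of fluorine, with the two halogens placed differently on the ring, therefore brings no readable shift here. Nothing available explains this result. Still open, going by these compounds, is whether an unsubstituted phenyl, a phenyl carrying an amine or a carboxylic acid, or a plain methyl in place of the ring would move the number beyond the scatter.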